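The source may report more compounds than this note shows. Statements on the series, on what has been measured and on what is new or still open speak of the compounds shown alone.

Measured in a functional assay on Daoy cells (Homo sapiens) for antiproliferative activity, read by trypan blue exclusion and crystal violet staining, with a stated time of 72 h; on this read-out higher numbers stand for weaker inhibition and lower numbers for stronger inhibition:
- Compound 1 `O=C(NCc1ccc2cccnc2c1O)C1CCCCC1`: 720 nM
- Compound 2 `COc1ccc(C(NC(C)=O)c2cc(Cl)c3cccnc3c2O)cc1OC`: 210 nM
- Compound 3 `CCCCC(=O)NCc1ccc2cccnc2c1O`: "nd" (no result reported)

Compound 3 has no single number in this assay, so any step from it can only be expected, not read. Compound 4 `CCCCC(=O)NC(c1cc(Cl)cc(Cl)c1)c1ccc2cccnc2c1O` is still unmeasured. The change is 3,5-dichlorophenyl in place of hydrogen on a saturated chain carbon bound to an amide-type nitrogen and an aromatic carbon.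

A moderate step towards stronger inhibition is expected. The hint is weak: compound 2, with an aromatic ring on such a carbon, gives 210 nM, and compound 1, without one, gives 720 nM, but these two also differ elsewhere.

For compound 4 the estimate is 300 nM, with an expected range of 90 nM to 1000 nM.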

Compound 4, half-maximal inhibitory concentration: 140 nM
Compound 4: middle estimate off by 2.1-fold (0.33 log units), on the high side; low and high end bracket the measured number.
By their numbers in this assay, from the lowest: compounds 4 and 2 (each within the scatter of the next); then compound 1.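

In this assay compound 3 has no single number, so the step to compound 4 cannot be read. What the 3,5-dichlorophenyl group itself contributes stays open, and no measurement shown here bears on this result.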